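Adding a Second Fluorine to a Carbamate Lactone

A few compounds are considered here, and "the series" means these few. Any claim that something is new, unique, unknown or untested is made for them only; others in the source may bear on it.

Measured compounds:
compound 1 `C=C1C(=O)OC[C@@H]1CCOC(=O)Nc1ccccc1`: 780 nM
compound 2 `C=C1C(=O)OC[C@H]1CCOC(=O)Nc1ccccc1F`: 350 nM
compound 3 `C=C1C(=O)OC[C@@H]1CCOC(=O)Nc1ccccc1F`: 690 nM

All three were tested in a functional assay on RAW264.7 cells (Mus musculus) for inhibition, with a stated time of 30 min; a lower number here means a stronger inhibitor, a higher number a weaker inhibitor. Compound 1 and compound 2 differ in more than one place, so the difference between the two cores is not broken down here. Compound 1 and compound 3 differ by fluoro in place of hydrogen on an aromatic carbon, a step of a 1.1-fold lower number from compound 1 to compound 3 (0.05 log units; within the scatter). Compound 2 and compound 3 give a 2.0-fold higher number from compound 2 to compound 3 (0.29 log units; within the scatter), which rests on (the fact that compounds 2 and 3 differ only in the configuration as drawn).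

Compound 4 `C=C1C(=O)OC[C@H]1CCOC(=O)Nc1ccc(F)cc1F` is not yet measured. It differs from compound 2 by fluoro in place of hydrogen on an aromatic carbon, the same kind of change as from compound 1 to compound 3, but the new fluoro sits meta to a fluoro group and para to a large group rather than ortho to a large group. Since compound 1 to compound 3 gave a 1.1-fold lower number from compound 1 to compound 3 (0.05 log units; within the scatter), a similar small step is expected, a 1.1-fold lower number from compound 2 to compound 4 (0.04 log units; within the scatter). Compound 4 is therefore estimated at 320 nM, likely between 130 nM and 800 nM.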

Compound 4, half-maximal inhibitory concentration: 330 nM
The estimate for compound 4 lay 1.0-fold (0.01 log units) below the measured number; the range from low to high includes it.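

Fluoro in place of hydrogen, here meta to a fluoro group and para to a large group, gives a 1.1-fold lower number from compound 2 to compound 4 (0.03 log units; within the scatter) in this assay. Set beside the step on the core of compound 1, the two steps agree:  the same change on two cores in this assay, a 1.1-fold lower number (0.05 log units; within the scatter) from compound 1 to compound 3 and a 1.1-fold lower number (0.03 log units; within the scatter) from compound 2 to compound 4, 1.1-fold (0.03 log units) apart, within the scatter of two such steps

So on these two cores the change behaves alike, with neither step large enough to be told from repeat scatter; this does not show that the same would hold on any other core, or that the fluoro has any real effect on the number.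

The compounds shown leave open whether a larger group on the aromatic ring, such as chloro, methoxy or trifluoromethyl, would move the number. They also leave open whether a longer chain between the lactone and the carbamate would do so.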